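Ethyl for Methyl on the Sulfonamide: Expected Loss of Potency

The source may hold more compounds than are shown below. What is called first, only, known or untested is meant among the compounds shown, and "the series" means these compounds.

Compound 1 `CS(=O)(=O)Nc1ccc(NC(=O)c2ccc(Cl)cc2)cc1Cl` was examined in an ADME assay on RAW264.7 cells (Mus musculus) for cytotoxicity, read by MTT assay, with a stated time of 48 h (a lower number here means a stronger inhibitor, a higher number a weaker inhibitor), where compound 1 gives 79900 nM. Compound 2 `CCS(=O)(=O)Nc1ccc(NC(=O)c2ccc(Cl)cc2)cc1Cl` differs from compound 1 by methyl in place of hydrogen on a saturated chain carbon bound to a sulfonyl sulfur. In this assay compound 2 reaches only a limit of the assay, > 250000 nM. The change therefore made an at least 3.1-fold higher number from compound 1 to compound 2 (0.49 log units; beyond the scatter), a step read against (the limit of > 250000 nM in this assay, at which 1 of the 3 values shown sits).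

Compound 3 `CS(=O)(=O)Nc1ccc(NC(=O)c2ccc(Cl)cc2)cc1F` differs from compound 1 by fluoro in place of chloro on an aromatic carbon, and this is also how the two cores differ. In this assay compound 3 gives 22300 nM, so that step is a 3.6-fold lower number from compound 1 to compound 3 (0.55 log units; beyond the scatter).

Compound 4 `CCS(=O)(=O)Nc1ccc(NC(=O)c2ccc(Cl)cc2)cc1F` differs from compound 3 by methyl in place of hydrogen on a saturated chain carbon bound to a sulfonyl sulfur. The place of the change is worded identically for both pairs, so it is the same change as from compound 1 to compound 2. Set beside an at least 3.1-fold higher number from compound 1 to compound 2 (0.49 log units; beyond the scatter), the step from compound 3 to compound 4 is expected to be a 3.6-fold higher number from compound 3 to compound 4 (0.55 log units; beyond the scatter). On that basis compound 4 is expected to give 80000 nM in this assay, with the estimate spanning 30000 nM to 250000 nM.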

Compound 4, half-maximal inhibitory concentration: 152000 nM
Estimate against measurement, compound 4: 1.9-fold (0.28 log units) below; the measured number falls inside the stated range.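

In this assay, ethyl in place of methyl on the sulfonyl raises the number on both cores, and on the core of compound 3 the step reads in full as a 6.8-fold higher number from compound 3 to compound 4 (0.83 log units; beyond the scatter). This shows that the direction of the change carries from the core of compound 1 to the core of compound 3, but it does not show whether the size carries too: the same change on two cores in this assay, an at least 3.1-fold higher number (0.49 log units; beyond the scatter) from compound 1 to compound 2 and a 6.8-fold higher number (0.83 log units; beyond the scatter) from compound 3 to compound 4; the limit leaves it open whether they differ The fluoro for chloro step on the ethyl pair, an at least 1.6-fold lower number from compound 2 to compound 4 (0.21 log units; that floor lies within the scatter), rests on a limit of the assay and is only a floor, so it cannot settle whether that change carries over in size either: the same change on two cores in this assay, a 3.6-fold lower number (0.55 log units; beyond the scatter) from compound 1 to compound 3 and an at least 1.6-fold lower number (0.21 log units; that floor lies within the scatter) from compound 2 to compound 4; the limit leaves it open whether they differ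

The compounds shown leave open whether a longer chain such as propyl on the sulfonyl would raise the number further, or whether the rise stops at ethyl. They also leave open how bromo or a plain hydrogen in place of the fluoro or chloro would behave alongside either sulfonyl group.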